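This account rests on a few compounds, and the source may have more. Where it says the series, first, only, none or still open, it means among the compounds named here.

Of the compounds shown here, two that share one core have been measured in a functional assay on A549 cells (Homo sapiens) for cytotoxicity, read by MTT assay, with a stated time of 48 h; a lower number here means a stronger inhibitor, a higher number a weaker inhibitor. Compound 1 `Cc1ccc(S(=O)(=O)/N=C(/CCNC2=CC(=O)c3ccccc3C2=O)Nc2cccc(C)c2)cc1` gives 18700 nM in this assay, and compound 2 `COc1ccc(N/C(CCNC2=CC(=O)c3ccccc3C2=O)=N\S(=O)(=O)c2ccc(C)cc2)cc1OC` gives 20500 nM. Compound 1 holds the lowest of the two numbers, yet its nearest neighbour, compound 2, sits within the scatter of it, so the two show no order. Going by the values given here, the one step between them, a 1.1-fold higher number from compound 1 to compound 2 (0.04 log units; within the scatter), exchanges one aromatic group for another on the amine nitrogen. Compound 3 `Cc1ccc(S(=O)(=O)/N=C(/CCNC2=CC(=O)c3ccccc3C2=O)NC(C)C)cc1` has not yet been measured in this assay. It differs from compound 1 by isopropyl in place of 3-methylphenyl on an amine nitrogen. Among the compounds with values here, no measured step exchanges an aromatic group for an alkyl group at this nitrogen, so the step from compound 1 to compound 2 bears only loosely on this change; it shows merely that one alteration of the group on that nitrogen left the number within the scatter. On that basis no step beyond the scatter is expected in this assay, and the estimated step is a 1.2-fold higher number from compound 1 to compound 3 (0.07 log units; within the scatter). Compound 3 is therefore expected to give about 22000 nM in this assay, within a range from 8000 nM to 60000 nM.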

Compound 3, half-maximal inhibitory concentration: 44300 nM
Compound 3: middle estimate off by 2.0-fold (0.30 log units), on the low side; the range from low to high includes it.
By their numbers in this assay, from the lowest: compounds 1 and 2 (each within the scatter of the next); then compound 3.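

In this assay, replacing an aromatic group with an alkyl group on the amine nitrogen moves the number beyond the scatter, which the exchange of one aromatic group for another did not do. Isopropyl in place of 3-methylphenyl gives (a 2.4-fold higher number from compound 1 to compound 3 (0.37 log units; beyond the scatter)), and isopropyl in place of 3,4-dimethoxyphenyl gives (a 2.2-fold higher number from compound 2 to compound 3 (0.33 log units; beyond the scatter)), so both modest steps run in the same direction, towards a weaker inhibitor, from two starting points that lie within the scatter of each other. Among these compounds, then, the position tolerates a change between the two substituted phenyl groups but not, without a modest loss, the change to isopropyl, though nothing offered here speaks to the reason for this rise.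

The compounds shown leave open whether the aromatic ring itself matters or whether any ring would serve, as a cyclohexyl group on this nitrogen would show. They also leave open how a benzyl group, a longer alkyl chain, or a phenyl ring bearing a chlorine atom or a carboxylic acid would stand in this assay against these three compounds.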